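The source may hold more compounds than are shown below. What is called first, only, known or untested is meant among the compounds shown, and "the series" means these compounds.

Compound 1 `O=C(O)C1=Cc2ccccc2OC1(OCc1cc(-c2ccc(F)cc2)no1)C(F)(F)F` is one of three compounds that have been measured in a functional assay on A549 cells (Homo sapiens) for inhibition, read by MTT assay, with a stated time of 24 h; a higher number here means a weaker inhibitor, a lower number a stronger inhibitor. In this assay compound 1 gives > 150000 nM, which is a limit of the assay rather than a number. Compound 2 `CCOC(=O)C1=Cc2ccccc2OC1(OCc1cc(-c2ccc(OC)cc2)no1)C(F)(F)F` likewise reaches only a limit in this assay, at > 150000 nM. Going by the values given here, compound 3 `CCOC(=O)C1=Cc2ccccc2OC1(OCc1cn(CC(=O)Nc2ccc(C)cc2)nn1)C(F)(F)F` is the one compound of the three with a numerical value in this assay, where it gives 54300 nM. Among the compounds with values here, compound 1 therefore stands at the limit of > 150000 nM in this assay, at which 2 of the 3 values shown sit, and no pair of measured compounds differing in one place is available, so there is no measured step from which a direction could be read.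

Compound 4 `O=C(O)C1=Cc2ccccc2OC1(OCc1cc(-c2ccc([N+](=O)[O-])cc2)no1)C(F)(F)F` has not yet been measured in this assay. It differs from compound 1 by nitro in place of fluoro on an aromatic carbon. Compound 1 and compound 2 both sit at limits, and the measured compounds give no indication of how this change would move the value. The expectation is that compound 4 also sits at or near a limit, with the step of a number no higher from compound 1 to compound 4 (the limit leaves the size open) expected to be none beyond the scatter. For compound 4 the estimate in this assay is 150000 nM, with a range from 40000 nM to 500000 nM.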

Compound 4, half-maximal inhibitory concentration: > 150000 nM
Compound 4 was reported as a limit; the forecaster's own chance of this, stated with the estimate: 70%; the middle value lies on the limit itself.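

In this assay, going by these compounds alone, compound 1 and compound 4 both stand at a limit of the assay rather than at a number, so no step from 4-fluorophenyl to 4-nitrophenyl can be read between them: the limit of > 150000 nM in this assay, at which 3 of the 4 values shown sit. The compounds shown leave open whether nitro in place of fluoro on an aromatic carbon moves the value in either direction.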